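This account rests on a few compounds, and the source may have more. Where it says the series, first, only, none or still open, it means among the compounds named here.

Measured so far in a functional assay on A549 cells (Homo sapiens) for antiproliferative activity, read by MTT assay, with a stated time of 72 h; on this read-out higher numbers stand for weaker inhibition and lower numbers for stronger inhibition:
Compound 1 `COc1cc2ncnc(Nc3ccc(F)c(Cl)c3)c2cc1OCCCCC(=O)Nc1ccc(S(N)(=O)=O)cc1` gives 15500 nM.
Compound 2 `COc1ccc(Nc2ncnc3cc(OC)c(OCCCCC(=O)Nc4ccc(S(N)(=O)=O)cc4)cc23)cc1` gives only a limit, > 40000 nM.
Compound 3 `COc1ccc(Nc2ncnc3cc(OC)c(OCCCCC(=O)Nc4ccc(S(N)(=O)=O)cc4)cc23)cc1OC` gives only a limit, > 40000 nM.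

Compound 3 thus stands at the edge of what this assay reports (the limit of > 40000 nM in this assay, at which 2 of the 3 values shown sit), with no number of its own. Compound 4 `COc1cc2ncnc(Nc3ccc(OC(F)(F)F)cc3)c2cc1OCCCCC(=O)Nc1ccc(S(N)(=O)=O)cc1` differs from it by 4-(trifluoromethoxy)phenyl in place of 3,4-dimethoxyphenyl on a nitrogen on an aromatic ring. Among the measured compounds shown here, two measured steps bear on this place: an at least 2.5-fold higher number from compound 1 to compound 2 (0.41 log units; beyond the scatter) and an at least 2.5-fold higher number from compound 1 to compound 3 (0.41 log units; beyond the scatter), both exchanging the same aryl group and both weakening, while a step that the two limits leave unreadable from compound 2 to compound 3 cannot be read. Compound 3 sits at a limit, so the size of the step to compound 4 cannot be read from the data either. Compound 4 is estimated at 25000 nM, with a range from 8000 nM to 40000 nM. This estimate corresponds to an expected step of an at least 1.6-fold lower number from compound 3 to compound 4 (0.20 log units; that floor lies within the scatter).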

Compound 4, half-maximal inhibitory concentration: > 40000 nM
Compound 4 ended at the assay's limit; the forecaster's own chance of this, stated with the estimate: 45%; middle value at least 1.6-fold (0.20 log units) away from the limit.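

The change to 4-(trifluoromethoxy)phenyl from 3-chloro-4-fluorophenyl gives an at least 2.5-fold higher number from compound 1 to compound 4 (0.41 log units; beyond the scatter) and so adds a third aryl group on this nitrogen that moves the same way as the two methoxy-bearing groups. Only compound 1 keeps a number of its own, and the steps among compound 2, compound 3 and compound 4 cannot be read: the limit of > 40000 nM in this assay, at which 3 of the 4 values shown sit.

Still open, from the compounds shown here alone, is whether a 3-chlorophenyl or a 4-fluorophenyl group on this nitrogen would give a measurable number. Also open, going by these compounds, is whether a shorter chain would bring compound 4 off the limit.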